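Saturating Both Arms of a Sulfonylurea Amine

A few compounds are considered here, and "the series" means these few. Any claim that something is new, unique, unknown or untested is made for them only; others in the source may bear on it.

Compound 2 `C=CCN(CC=C)S(=O)(=O)NC(=O)Nc1c(C(C)C)cccc1C(C)C` holds the higher of the two numbers recorded so far: in an assay on liver for inhibition of sterol O-acyltransferase 1 (Rattus norvegicus), using microsomes (on this read-out lower numbers stand for stronger inhibition and higher numbers for weaker inhibition), compound 2 gives 2700 nM, while compound 1 `C=CCN(CC)S(=O)(=O)NC(=O)Nc1c(C(C)C)cccc1C(C)C` gives 2100 nM. Among the measured compounds shown here, the one measured step, a 1.3-fold higher number from compound 1 to compound 2 (0.11 log units; within the scatter), shows that exchanging a saturated for an unsaturated arm on this amine changed little. Compound 3 `CCCN(CCC)S(=O)(=O)NC(=O)Nc1c(C(C)C)cccc1C(C)C` differs from compound 2 in one place: dipropylamino in place of diallylamino on a sulfonyl sulfur. For the measured compounds named here, because the only step that bears on this part of the molecule, a 1.3-fold higher number from compound 1 to compound 2 (0.11 log units; within the scatter), stayed within the scatter, no shift beyond the scatter is expected for compound 3 in this assay: a 1.1-fold lower number from compound 2 to compound 3 (0.03 log units; within the scatter). Compound 3 is therefore estimated at 2500 nM, within a range from 1200 nM to 5500 nM.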

Compound 3, half-maximal inhibitory concentration: 1100 nM
Compound 3: middle estimate off by 2.3-fold (0.36 log units), on the high side; measured number outside the range, below it.
By their numbers in this assay, from the lowest: compounds 3, 1 and 2 (each within the scatter of the next, the first and the last beyond it).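

In this assay the exchange of diallylamino for dipropylamino gives a 2.5-fold lower number from compound 2 to compound 3 (0.39 log units; beyond the scatter) and is a modest step, the only one at this sulfonyl sulfur to pass the scatter. Exchanging allyl(ethyl)amino for dipropylamino gives a 1.9-fold lower number from compound 1 to compound 3 (0.28 log units; within the scatter) and stays within it, so here only replacing both unsaturated arms separates two compounds. Nothing available here explains the difference between these steps.

As far as these compounds go, whether a longer chain such as dibutylamino, or a ring such as piperidine, on the sulfonyl sulfur would lower the number further remains open.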